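From 1-methylcyclopropyl to cyclobutyl in compound 2

The compounds below may be only part of what the source reports. "The series", "measured", "known", "first", "only" and "open" are said of these compounds alone.

Compound 1 `COC(=O)CC/C=C\CC[C@H]1C(=O)C[C@@H](O)[C@@H]1/C=C/CC(C)(O)CCC1CCCC1`: 1.31 mg/kg
Compound 2 `COC(=O)CC/C=C\CC[C@H]1C(=O)C[C@@H](O)[C@@H]1/C=C/C[C@@](C)(O)/C=C/C1(C)CC1`: 1.34 mg/kg

Within the data shown here, in a functional assay on the whole organism with Rattus norvegicus as the target (a lower number here means that less compound is needed, a higher number that more compound is needed for the effect), compound 2 gives 1.34 mg/kg, which cannot be told apart from the value of compound 1, the only other compound measured. The next compound to be tested is compound 3 `COC(=O)CC/C=C\CC[C@H]1C(=O)C[C@@H](O)[C@@H]1/C=C/C[C@@](C)(O)/C=C/C1CCC1`. It keeps the shared core and differs from compound 2 in one group: cyclobutyl in place of 1-methylcyclopropyl on a double-bonded chain carbon bound to a double-bonded chain carbon. Cyclobutyl stands in place of 1-methylcyclopropyl, on a double-bonded chain carbon bound to a double-bonded chain carbon.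

Among the measured compounds shown here, only one measured step bears on this change, and only indirectly. In a 1.0-fold higher number from compound 1 to compound 2 (0.01 log units; within the scatter), 1-hydroxy-1-methyl-3-(1-methylcyclopropyl)prop-2-en-1-yl replaces 3-cyclopentyl-1-hydroxy-1-methylpropyl, and that step stays within the scatter. For the measured compounds named here, no measured step isolates the exchange of 1-methylcyclopropyl for cyclobutyl, so the direction of any shift in this assay remains open, and a step beyond the scatter is not expected. The expected change is a 1.0-fold higher number from compound 2 to compound 3 (0.02 log units; within the scatter). For compound 3 the estimate is 1.4 mg/kg, with an expected range from 0.6 mg/kg to 3.5 mg/kg.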

Compound 3, dose for half-maximal effect: 0.53 mg/kg
For compound 3 the middle estimate is 2.6-fold (0.42 log units) above the measured one; measured number outside the range, below it.
By their numbers in this assay, from the lowest: compound 3; then compounds 1 and 2 (each within the scatter of the next).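

In this assay, the exchange of 1-methylcyclopropyl for cyclobutyl gives a 2.5-fold lower number from compound 2 to compound 3 (0.40 log units; beyond the scatter) and so shows that this place, on a double-bonded chain carbon bound to a double-bonded chain carbon, responds to a swap between two groups of equal heavy-atom count, each a non-aromatic ring of carbon only. The earlier step, a 1.0-fold higher number from compound 1 to compound 2 (0.01 log units; within the scatter) for a larger replacement, gave no sign of this, whereas 3-cyclobutyl-1-hydroxy-1-methylprop-2-en-1-yl in place of 3-cyclopentyl-1-hydroxy-1-methylpropyl gives a 2.5-fold lower number from compound 1 to compound 3 (0.39 log units; beyond the scatter) and moves beyond the scatter where the 1-methylcyclopropyl version did not. Nothing given here accounts for the difference between the two groups.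

The compounds shown leave open whether ring size or the loss of the methyl group goes with the lower number, since the change from 1-methylcyclopropyl to cyclobutyl alters both at once. Plain cyclopropyl and 1-methylcyclobutyl at this same place would pull the two apart, and whether cyclopentyl on the double-bonded chain carbon continues the same way also remains unknown.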